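Replacing the 4-chlorobenzyl group on the ring amine nitrogen

The source may hold more compounds than are shown below. What is called first, only, known or untested is meant among the compounds shown, and "the series" means these compounds.

Measured so far in a functional assay on HL-60 cells (Homo sapiens) for antiproliferative activity, with a stated time of 24 h; on this read-out higher numbers stand for weaker inhibition and lower numbers for stronger inhibition:
Compound 1, `NC(=O)c1c(NC(=O)c2ccccc2Cl)sc2c1CCN(Cc1ccc(Cl)cc1)C2`, gives 22500 nM.
Compound 3, `Cc1ccc(C(=O)Nc2sc3c(c2C(N)=O)CCN(Cc2ccc(Cl)cc2Cl)C3)cc1`, gives 19900 nM.
Compound 2, `NC(=O)c1c(NC(=O)c2ccc(C(F)(F)F)cc2)sc2c1CCN(Cc1ccc(Cl)cc1)C2`, reaches only the limit of this assay, > 50000 nM.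

Compound 1 holds the highest of the two numbers in this assay; compound 3 sits within the scatter of it, and the third value is a limit. Among the measured compounds shown here, the only step measured on a single change, an at least 2.2-fold higher number from compound 1 to compound 2 (0.34 log units; beyond the scatter), concerns the aryl on the carbonyl carbon and ends at a limit (the limit of > 50000 nM in this assay, at which 1 of the 3 values shown sits).

Compound 4, `NC(=O)c1c(NC(=O)c2ccccc2Cl)sc2c1CCN(C(=S)Nc1ccccc1I)C2`, differs from compound 1 at a different place: a group of 10 heavy atoms (7 carbon, 1 nitrogen, 1 sulfur, 1 iodine; one six-membered aromatic ring of carbon only) in place of a group of 8 heavy atoms (7 carbon, 1 chlorine; one six-membered aromatic ring of carbon only), on an amine nitrogen in a ring. For the measured compounds named here, no measured step touches the amine nitrogen in the ring, so no change beyond the scatter is expected in this assay. The estimate for compound 4 is 22000 nM, between 7000 nM and 50000 nM, which is expected to mean a 1.0-fold lower number from compound 1 to compound 4 (0.01 log units; within the scatter).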

Compound 4, half-maximal inhibitory concentration: 4430 nM
The estimate for compound 4 lay 5.0-fold (0.70 log units) above the measured number; the whole stated range lies above it.
By their numbers in this assay, from the lowest: compound 4; then compounds 3 and 1 (each within the scatter of the next). At a limit, above all of these: compound 2.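

The amine nitrogen in the ring is a position that responds in this assay: with the 2-chlorophenyl on the carbonyl carbon held constant, the change away from 4-chlorobenzyl gives a 5.1-fold lower number from compound 1 to compound 4 (0.71 log units; beyond the scatter). The entering group differs in its nitrogen, sulfur, iodine and hydrogen-bond donor at once, and this single step cannot assign the change to any one of them. No measurement shown bears on the cause of this step.

Open, going by these compounds, is how a urea carbonyl in place of the sulfur-bearing double bond, or a phenyl without iodine, would compare. Also open, on these data alone, is whether the step holds with 4-(trifluoromethyl)phenyl on the carbonyl carbon.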